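Piperazine-linked dichlorophenoxy pyrimidines: amide to urea

The source may report more compounds than this note shows. Statements on the series, on what has been measured and on what is new or still open speak of the compounds shown alone.

Of the compounds shown here, two have numbers so far. Compound 1 `O=C(c1cc(Cl)ccn1)N1CCN(c2nccc(Oc3cc(Cl)cc(Cl)c3)n2)CC1` carries a (4-chloropyridin-2-yl)carbonyl on the piperazine nitrogen; in a functional assay on MDA-MB-231 cells (Homo sapiens) for antiproliferative activity, read by MTT assay, with a stated time of 24 h (a higher number here means a weaker inhibitor, a lower number a stronger inhibitor), compound 1 gives 16700 nM. Compound 2 `N#Cc1ccc(S(=O)(=O)N2CCN(c3nccc(Oc4cc(Cl)cc(Cl)c4)n3)CC2)cc1` replaces that carbonyl arm with a sulfonyl-linked cyanophenyl group; in this assay compound 2 gives 24800 nM. Compound 1 has the lower of the two numbers, but the gap to compound 2 lies inside the usual scatter, so the two cannot be told apart.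

Compound 3 `Cc1ccc(NC(=O)N2CCN(c3nccc(Oc4cc(Cl)cc(Cl)c4)n3)CC2)cc1` is the next member to be tested. It differs from compound 1 at the carbonyl carbon only: (4-methylphenyl)amino in place of 4-chloropyridin-2-yl on a carbonyl carbon. Among the measured compounds shown here, no measured pair in this set shows what such a change does, so the step in this assay is expected to be small, if anything a slight move to a lower number, and quite possibly no change beyond the scatter. The estimate for compound 3 is 15000 nM, with a range of 5000 nM to 45000 nM, which corresponds to an expected step of a 1.1-fold lower number from compound 1 to compound 3 (0.05 log units; within the scatter).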

Compound 3, half-maximal inhibitory concentration: 11600 nM
Compound 3: the middle estimate sits 1.3-fold (0.11 log units) above what was measured; the measured number falls inside the stated range.
By their numbers in this assay, from the lowest: compounds 3, 1 and 2 (each within the scatter of the next, the first and the last beyond it).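

Among the compounds shown here, the first measured step at this place, on a carbonyl carbon bound to an amide-type nitrogen in a ring, is a 1.4-fold lower number from compound 1 to compound 3 (0.16 log units; within the scatter) in this assay. The change from 4-chloropyridin-2-yl to (4-methylphenyl)amino turns the amide into a urea and brings in a hydrogen-bond donor that the leaving group lacks, yet compound 1 and compound 3 cannot be told apart in this read-out. No measured evidence bears on this result.

The compounds shown do not separate the amino link from the aryl group, so phenylamino and (4-chloropyridin-2-yl)amino on the same carbonyl carbon remain open. Also open, as far as these compounds go, is whether a small alkylamino group such as methylamino, or a ring amine such as morpholine, at this place would give a number beyond the scatter from compound 1.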